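Trifluoromethyl for Methyl on a Triazole-Linked Aryl Ring

The source may report more compounds than this note shows. Statements on the series, on what has been measured and on what is new or still open speak of the compounds shown alone.

compound 1: `Cc1c(O)ccc2c1[C@H](Cn1cc(-c3ccc(C(F)(F)F)cc3)nn1)[C@@]13CC(=O)[C@@](C)(CC[C@@H]21)C3` — > 20000 nM
compound 2: `Cc1ccc(-c2cn(C[C@H]3c4c(ccc(OS(=O)(=O)c5ccc(C)cc5)c4C)[C@@H]4CC[C@@]5(C)C[C@]43CC5=O)nn2)cc1` — > 20000 nM

In a functional assay on A549 cells (Homo sapiens) for cytotoxicity, read by MTT assay, with a stated time of 4 days (a higher number here means a weaker inhibitor, a lower number a stronger inhibitor), compound 1 gives > 20000 nM, which is a limit of the assay rather than a number. In this assay compound 2 likewise gives only a limit, > 20000 nM. For the measured compounds named here, both results therefore sit at the limit of > 20000 nM in this assay, at which 2 of the 2 values shown sit, so no measured step between them can be read.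

Compound 3 `Cc1ccc(S(=O)(=O)Oc2ccc3c(c2C)[C@H](Cn2cc(-c4ccc(C(F)(F)F)cc4)nn2)[C@@]24CC(=O)[C@@](C)(CC[C@@H]32)C4)cc1` differs from compound 2 in one place: trifluoromethyl in place of methyl on an aromatic carbon, para to a large group. Going by the values given here, no measured pair shows this change by itself. Compound 1, which already carries the trifluoromethyl group on the same ring, also sits at the limit of > 20000 nM in this assay, at which 2 of the 2 values shown sit. The step from compound 2 to compound 3, a step that the limit leaves unreadable from compound 2 to compound 3, is expected to stay within the scatter. Compound 3 is expected to give about 30000 nM, in the range 10000 nM to 100000 nM.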

Compound 3, half-maximal inhibitory concentration: > 20000 nM
Compound 3: only a limit was reported; the forecaster's own chance of this, stated with the estimate: 85%; the middle value does not contradict the limit.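

In this assay no step can be read from compound 2 to compound 3 or from compound 1 to compound 3, because all three results are limits and not numbers: the limit of > 20000 nM in this assay, at which 3 of the 3 values shown sit.

The compounds shown leave open how strongly any of them acts on these cells, and whether trifluoromethyl in place of methyl changes that at all.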